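Furan-linked phenyl ring: effect of a chloro substituent

A few compounds are considered here, and "the series" means these few. Any claim that something is new, unique, unknown or untested is made for them only; others in the source may bear on it.

Measured compounds:
- compound 1, `O=C(O)C(=O)CC(=O)c1cccc(Cl)c1`: 6960 nM
- compound 2, `O=C(O)C(=O)CC(=O)c1cccc(Oc2ccccc2)c1`: 7310 nM
- compound 3, `O=C(O)C(=O)CC(=O)c1ccc(-c2ccccc2)o1`: 1660 nM

In an assay on isolated protein for inhibition of Flap endonuclease 1 (Homo sapiens) (on this read-out higher numbers stand for weaker inhibition and lower numbers for stronger inhibition), compound 3 gives 1660 nM, the lowest of the three numbers. The gap to compound 1 and to compound 2 is beyond the usual scatter in both cases, so compound 3 stands apart as the strongest inhibitor of the three measured compounds.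

Compound 4, `O=C(O)C(=O)CC(=O)c1ccc(-c2ccc(Cl)cc2)o1`, is the next step from compound 3: chloro in place of hydrogen on an aromatic carbon, on an aromatic carbon of a six-membered aromatic ring of carbon only, para to a large group. Going by the values given here, no measured pair differs by exactly this exchange. Among the compounds with values here, the one measured step, a 1.1-fold higher number from compound 1 to compound 2 (0.02 log units; within the scatter), swaps one group for another on a different core and stayed within the scatter, so it offers little guidance here. Compound 1 does carry a chloro group, but its core is not that of compound 3, and no direct comparison exists. The expectation for compound 4 therefore rests on compound 3 alone, with a step of a 1.2-fold lower number from compound 3 to compound 4 (0.07 log units; within the scatter) expected, which is no change beyond the scatter. Compound 4 is estimated at 1400 nM in this assay, within a range from 450 nM to 4500 nM.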

Compound 4, half-maximal inhibitory concentration: 10800 nM
Estimate against measurement, compound 4: 7.7-fold (0.89 log units) below; measured number outside the range, above it.
By their numbers in this assay, from the lowest: compound 3; then compounds 1, 2 and 4 (each within the scatter of the next).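

Chloro in place of hydrogen, on an aromatic carbon of a six-membered aromatic ring of carbon only and para to a large group, gives a 6.5-fold higher number from compound 3 to compound 4 (0.81 log units; beyond the scatter) in this assay, so a change of 1 heavy atom here weakens inhibition. Going by these compounds alone, the earlier compounds could not show this: their only step, a 1.1-fold higher number from compound 1 to compound 2 (0.02 log units; within the scatter), lies on a different core and stays within the scatter, whereas this position clearly responds to a substituent. Nothing measured here explains the weaker inhibition.

Still open, from the compounds shown here alone, is whether this weakening is particular to chloro or would follow from other groups at the same position, such as fluoro, methyl, methoxy or hydroxy. Going by these compounds, it is also open whether chloro elsewhere on this ring would give a similar step.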